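Half-Life After One Group Changes on Compound 2

The compounds below may be only part of what the source reports. "The series", "measured", "known", "first", "only" and "open" are said of these compounds alone.

Compound 1 `CC(=O)c1cccc([C@@H](O)[C@H](O)[C@H](O)CO)n1` gives 2.1 h
Compound 2 `CC(O)c1nc([C@@H](O)[C@H](O)[C@H](O)CO)c[nH]1` gives 4.4 h

In an ADME assay on the whole organism (strain 129/SvEvBrd x C57BL/6) for metabolic stability, with Mus musculus as the target (on this read-out higher numbers stand for a longer-lived compound and lower numbers for a shorter-lived compound), compound 2 stands highest of the two measured compounds at 4.4 h, beyond the scatter from compound 1. Compound 3 `OC[C@@H](O)[C@@H](O)[C@H](O)c1c[nH]c(-c2cocn2)n1` carries 1,3-oxazol-4-yl in place of 1-hydroxyethyl on an aromatic carbon. Going by the values given here, no measured pair shows this change, so only a small downward step is expected, probably within the scatter. The expected step is a 1.5-fold lower number from compound 2 to compound 3 (0.17 log units; within the scatter). Compound 3 is estimated at 3 h, with an expected range of 1.3 h to 7 h.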

Compound 3, half-life: 1.2 h
The estimate for compound 3 lay 2.5-fold (0.40 log units) above the measured number; the whole stated range lies above it.
By their numbers in this assay, from the lowest: compounds 3 and 1 (each within the scatter of the next); then compound 2.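

On the aromatic carbon between two ring nitrogen atoms, 1,3-oxazol-4-yl in place of 1-hydroxyethyl gives, in this assay, a 3.7-fold lower number from compound 2 to compound 3 (0.56 log units; beyond the scatter). Going by these compounds alone, this is the first comparison here that differs in one place, and it shows that the half-life responds to the group at this position. No measurement here accounts for the size of this step.

As far as these compounds go, it remains open whether the loss of 1-hydroxyethyl or the arrival of 1,3-oxazol-4-yl governs the step. From the compounds shown here alone, how a methyl group or an amine on this carbon would compare also remains open.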